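Swapping the Aryl Group for Thiophene on a Triazolethione

The source may report more compounds than this note shows. Statements on the series, on what has been measured and on what is new or still open speak of the compounds shown alone.

Measured so far:
Compound 1 `CS(=O)(=O)c1ccc(Cc2n[nH]c(=S)n2/N=C/c2c(F)cccc2Cl)cc1`: 77.3%
Compound 2 `CS(=O)(=O)c1ccc(Cc2n[nH]c(=S)n2/N=C/c2ccccc2F)cc1`: 28.1%

Both compounds were tested in a functional assay on HeLa cells (Homo sapiens) for cytotoxicity, read by MTT assay, with a stated time of 48 h, tested at 100 uM; a lower number here means a weaker effect, a higher number a stronger effect of the compound at the concentration tested. Compound 2 stands at the lower of the two numbers; its nearest and only neighbour is compound 1, which lies higher by a margin said to be beyond the usual scatter. Going by the values given here, the single measured step, a number 49.2 percentage points lower from compound 1 to compound 2 (beyond the scatter), concerns the loss of a chloro group from an aromatic carbon and is large.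

Compound 3 `CS(=O)(=O)c1ccc(Cc2n[nH]c(=S)n2/N=C/c2cccs2)cc1` is not yet measured. It differs from compound 2 as follows: thiophen-2-yl in place of 2-fluorophenyl on a carbon with a double bond to nitrogen.

Among the compounds with values here, no measured step touches the group that changes here; the step from compound 1 to compound 2 alters a different part of the same ring, so it gives no direct guide to the size or direction of the present change. Within the data shown here, with only that one step available, and it unrelated, the expectation for compound 3 rests on compound 2 alone, with a wide band on either side. For compound 3 the estimated value in this assay is 35%, between 10% and 70%. The estimated step from compound 2 is therefore a number 6.9 percentage points higher from compound 2 to compound 3 (within the scatter), which is expected to be small against such a broad range.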

Compound 3, a percentage reported as activity, at one concentration (the size of the read-out at that concentration, not a potency): 61.1%
Estimate against measurement, compound 3: 26.1 percentage points below, and the stated range covers the measured number.
By their numbers in this assay, from the lowest: compound 2; then compound 3; then compound 1.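

In this assay, the carbon with a double bond to nitrogen tolerates more than a change of substituent on a phenyl ring: exchanging the whole ring for thiophen-2-yl gives a number 33 percentage points higher from compound 2 to compound 3 (beyond the scatter). The earlier pair showed only that adding or removing a chloro group on the phenyl ring matters, whereas this result shows that a five-membered aromatic ring with a sulfur atom and no halogen can also reach a high reading, though it does not fully match the chloro-bearing ring, with a number 16.2 percentage points lower from compound 1 to compound 3 (beyond the scatter). There is no evidence here to explain why the three rings differ.

The compounds shown leave open whether a chloro group on the thiophene would raise the reading further, as the chloro group does on the phenyl ring of compound 1, and whether a pyridin-2-yl ring or a non-aromatic cyclohexyl group would fit this place as well. Each reading also comes from a single concentration, so these compounds can be compared only by their stronger or weaker effect at that concentration.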